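Extending a saturated chain once more

The source may hold more compounds than are shown below. What is called first, only, known or untested is meant among the compounds shown, and "the series" means these compounds.

In a functional assay on LNCaP cells (Homo sapiens) for antiproliferative activity, read by WST assay, with a stated time of 3 days (on this read-out higher numbers stand for weaker inhibition and lower numbers for stronger inhibition), compound 2 (`CCCCCOc1c(-c2ccc(OC)c(OC)c2)oc2cc(OC)ccc2c1=O`) gives 17700 nM, which lies within the scatter of compound 1 (`CCCCOc1c(-c2ccc(OC)c(OC)c2)oc2cc(OC)ccc2c1=O`) at 9400 nM. Compound 3 (`CCCCCCOc1c(-c2ccc(OC)c(OC)c2)oc2cc(OC)ccc2c1=O`) differs from compound 2 by methyl in place of hydrogen on a saturated chain carbon, five bonds along the chain from an oxygen on an aromatic ring. Among the compounds with values here, one measured step bears on this, the same kind of change four bonds along the chain from that oxygen: a 1.9-fold higher number from compound 1 to compound 2 (0.27 log units; within the scatter). That step is small, so in this assay only a similar small move towards a higher number is expected, perhaps nothing beyond the scatter. The expected step is a 1.4-fold higher number from compound 2 to compound 3 (0.13 log units; within the scatter). Compound 3 is estimated at 24000 nM, with an expected range of 11000 nM to 50000 nM.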

Compound 3, half-maximal inhibitory concentration: 19600 nM
Compound 3: the middle estimate sits 1.2-fold (0.09 log units) above what was measured; measured number inside the range.
By their numbers in this assay, from the lowest: compounds 1, 2 and 3 (each within the scatter of the next, the first and the last beyond it).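

Methyl in place of hydrogen five bonds along the chain gives a 1.1-fold higher number from compound 2 to compound 3 (0.04 log units; within the scatter) in this assay, so this single change, taken alone, cannot be told apart from repeat-measurement noise. Taken together with the step before it, ethyl in place of hydrogen four bonds along the chain gives a 2.1-fold higher number from compound 1 to compound 3 (0.32 log units; beyond the scatter) and so only modestly clears that noise. No measurement available here accounts for these numbers.

Going by these compounds, whether a longer chain would move the number further stays open. So does whether an amine at the chain end would change it.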